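The source may hold more compounds than are shown below. What is called first, only, known or untested is meant among the compounds shown, and "the series" means these compounds.

Working notes on the series.

Compound 1 `CC[C@@H]1/C=C(\C)C[C@H](C)C[C@H](OC)[C@H]2O[C@@](O)(C(=O)C(=O)N3CCCC[C@H]3C(=O)O[C@H](/C(C)=C/[C@@H]3CC[C@@H](Oc4ccccc4)[C@H](OC)C3)[C@H](C)[C@@H](O)CC1=O)[C@H](C)C[C@@H]2OC` is the reference point. Within the data shown here, in a functional assay on cells for inhibition, with Murine T-cell line (Mus musculus) as the target (on this read-out lower numbers stand for stronger inhibition and higher numbers for weaker inhibition), compound 1 gives 5.4 nM, the highest of the three numbers measured so far. Among the measured compounds shown here, compound 3 `CC[C@@H]1/C=C(\C)C[C@H](C)C[C@H](OC)[C@H]2O[C@@](O)(C(=O)C(=O)N3CCCC[C@H]3C(=O)O[C@H](/C(C)=C/[C@@H]3CC[C@@H](Oc4ccccc4)[C@H](O)C3)[C@H](C)[C@@H](O)CC1=O)[C@H](C)C[C@@H]2OC` gives 5.2 nM in this assay, and the only single-point step available, a 1.0-fold lower number from compound 1 to compound 3 (0.02 log units; within the scatter), changes nothing outside the scatter. For the measured compounds named here, compound 2 `CC[C@@H]1/C=C(\C)C[C@H](C)C[C@H](OC)[C@H]2O[C@@](O)(C(=O)C(=O)N3CCCC[C@H]3C(=O)O[C@H](/C(C)=C/[C@@H]3CC[C@@H](O)[C@H](Oc4ccc(C)cc4)C3)[C@H](C)[C@@H](O)CC1=O)[C@H](C)C[C@@H]2OC` gives 2.6 nM, the lowest number of the three, but it differs from compound 1 in more than one place, so no single step can be drawn from that pair; its value shows only that a methyl-bearing aromatic ring is compatible with a low number.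

Compound 4 `CC[C@@H]1/C=C(\C)C[C@H](C)C[C@H](OC)[C@H]2O[C@@](O)(C(=O)C(=O)N3CCCC[C@H]3C(=O)O[C@H](/C(C)=C/[C@@H]3CC[C@@H](Oc4ccc(OC)cc4)[C@H](OC)C3)[C@H](C)[C@@H](O)CC1=O)[C@H](C)C[C@@H]2OC` differs from compound 1 by methoxy in place of hydrogen on an aromatic carbon. No measured step concerns a substituent on the aromatic ring, so the expectation rests on the general tolerance the series has shown: one step within the scatter, one lower number with a ring substituent. Compound 4 is therefore expected to move by about a 1.2-fold lower number from compound 1 to compound 4 (0.08 log units; within the scatter), a step inside the scatter. The estimate for compound 4 is 4.5 nM, in the range 2 nM to 10 nM.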

Compound 4, half-maximal inhibitory concentration: 1.4 nM
The estimate for compound 4 lay 3.2-fold (0.51 log units) above the measured number, outside the stated range (below it).
By their numbers in this assay, from the lowest: compounds 4, 2, 3 and 1 (each within the scatter of the next, the first and the last beyond it).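

In this assay, among these compounds, methoxy in place of hydrogen on the aromatic carbon para to a large group gives a 3.9-fold lower number from compound 1 to compound 4 (0.59 log units; beyond the scatter), the first single-place step that lies beyond the scatter. Among the compounds shown here, the only earlier step, a 1.0-fold lower number from compound 1 to compound 3 (0.02 log units; within the scatter), concerned a methyl on an oxygen on a saturated carbon, so the phenoxy to 4-methoxyphenoxy change shows that this aromatic position, unlike that oxygen, registers a change in the read-out. Nothing available explains this step.

Going by these compounds, it remains open whether the lower number is specific to methoxy or would also appear with a hydroxyl, an amine or a longer chain such as ethoxy on the same aromatic carbon. Also open, on these data alone, is whether the same change would give a step of similar size when made on compound 3.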